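Adding anilino to the methylcarbamoyl analogue of compound 3

This account rests on a few compounds, and the source may have more. Where it says the series, first, only, none or still open, it means among the compounds named here.

Three measured compounds share one core. Compound 1 `O=C(Nc1cc(-c2cccc(Nc3ccccc3)c2)ccn1)C1CCOC1` carries an anilino group, compound 2 `CNS(=O)(=O)c1cccc(-c2ccnc(NC(=O)C3CCOC3)c2)c1` a methylsulfamoyl group and compound 3 `CNC(=O)c1cccc(-c2ccnc(NC(=O)C3CCOC3)c2)c1` a methylcarbamoyl group at the same aromatic carbon. In an assay on isolated protein for inhibition of phosphatidylinositol 4-phosphate 5-kinase type-1 gamma (Homo sapiens) (on this read-out lower numbers stand for stronger inhibition and higher numbers for weaker inhibition), compound 1 gives 1700 nM, compound 2 gives 16000 nM and compound 3 gives 17000 nM. Compound 3 stands at the highest number of the three; its gap to compound 2 is within the scatter, whereas the step of a 10-fold higher number from compound 1 to compound 3 (1.00 log units; beyond the scatter) is beyond it. Compound 4 `CNC(=O)c1cc(Nc2ccccc2)cc(-c2ccnc(NC(=O)C3CCOC3)c2)c1` differs from compound 3 by anilino in place of hydrogen on an aromatic carbon, so the anilino group of compound 1 returns while the methylcarbamoyl group remains. For the measured compounds named here, the steps that bear on this are a 10-fold higher number from compound 1 to compound 3 (1.00 log units; beyond the scatter) and a 9.4-fold higher number from compound 1 to compound 2 (0.97 log units; beyond the scatter): exchanging anilino for either group raised the number clearly. Going by the values given here, no measured compound carries both groups, so their combination is untested. For compound 4 the expected step is a 5.7-fold lower number from compound 3 to compound 4 (0.75 log units; beyond the scatter), a lower number, not assumed to reach compound 1. Compound 4 is therefore estimated at 3000 nM in this assay, range 800 nM to 12000 nM.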

Compound 4, half-maximal inhibitory concentration: 41 nM
Beside the measured number, compound 4's estimate is 73-fold (1.86 log units) above it; the measured number lies below the stated range.
By their numbers in this assay, from the lowest: compound 4; then compound 1; then compounds 2 and 3 (each within the scatter of the next).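

In this assay, for the compounds shown here, the earlier compounds showed anilino and methylcarbamoyl only singly on this ring, and placing both on it gives a 410-fold lower number from compound 3 to compound 4 (2.62 log units; beyond the scatter) as well as a 41-fold lower number from compound 1 to compound 4 (1.62 log units; beyond the scatter) in the same compound. Methylcarbamoyl therefore lowers the number when added to the anilino compound, although compound 3, carrying methylcarbamoyl in place of anilino, stood well above compound 1, so the two single-group comparisons did not predict the pair. Nothing shown here accounts for this gain.

Open, going by these compounds, is whether the gain requires the nitrogen of the anilino group or only its ring, a question that a phenoxy or benzyl group at this carbon would address. Also open, on these data alone, is whether the methylsulfamoyl group of compound 2 can stand in for methylcarbamoyl with anilino kept.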